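The source may hold more compounds than are shown below. What is called first, only, known or untested is meant among the compounds shown, and "the series" means these compounds.

Measured compounds:
- compound 1, `O=C(COc1ccc(/C=C2\SC(=O)NC2=O)cc1)Nc1ccc(F)cc1`: in a functional assay on MCF7 cells (Homo sapiens) for inhibition (a lower number here means a stronger inhibitor of growth, a higher number a weaker inhibitor of growth), compound 1 gives 54600 nM
- compound 2, `O=C(COc1ccc(/C=C2\SC(=O)NC2=O)cc1)Nc1ccccc1`: compound 2 gives 74500 nM
- compound 3, `O=C(COc1ccc(/C=C2\SC(=O)NC2=O)cc1)Nc1ccc(Br)cc1`: compound 3 gives 55100 nM

Compound 3 stands second highest of these three numbers, but its nearest neighbour is compound 1, with a 1.0-fold higher number from compound 1 to compound 3 (0.00 log units; within the scatter), and the step of a 1.4-fold lower number from compound 2 to compound 3 (0.13 log units; within the scatter) is also within the scatter, so the three measured compounds cannot be told apart in this assay. The step of a 1.4-fold higher number from compound 1 to compound 2 (0.13 log units; within the scatter) confirms that exchanging the substituent on the aryl amide has so far moved nothing beyond the scatter.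

Compound 4, `O=C(COc1ccc(/C=C2\SC(=O)NC2=O)cc1)Nc1c(Cl)cccc1Cl`, differs from compound 3 by 2,6-dichlorophenyl in place of 4-bromophenyl on an amide-type nitrogen. For the measured compounds named here, none of the measured steps covers this exact change, since all three measured compounds carry either hydrogen or a single halogen at the same position of the phenyl ring; the only guidance is that every variation at the aryl amide so far, a 1.0-fold higher number from compound 1 to compound 3 (0.00 log units; within the scatter) and a 1.4-fold lower number from compound 2 to compound 3 (0.13 log units; within the scatter), stayed within the scatter. Compound 4 is therefore expected to show a 1.1-fold higher number from compound 3 to compound 4 (0.04 log units; within the scatter), no step beyond the scatter. The estimate for compound 4 is 60000 nM, with a range from 25000 nM to 150000 nM.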

Compound 4, concentration for 50% growth inhibition: 61700 nM
Estimate against measurement, compound 4: 1.0-fold (0.01 log units) below; the range from low to high includes it.
By their numbers in this assay, from the lowest: compounds 1, 3, 4 and 2 (each within the scatter of the next).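

In this assay, 2,6-dichlorophenyl on the amide-type nitrogen cannot be told apart from 4-bromophenyl (a 1.1-fold higher number from compound 3 to compound 4 (0.05 log units; within the scatter)), from 4-fluorophenyl (a 1.1-fold higher number from compound 1 to compound 4 (0.05 log units; within the scatter)) or from phenyl (a 1.2-fold lower number from compound 2 to compound 4 (0.08 log units; within the scatter)). The earlier compounds compared only hydrogen and a single halogen at one place on the ring, and the insensitivity seen there now extends to a differently substituted ring, so no aryl exchange among these four compounds separates any pair. Nothing available bears on the reason for this flat result.

All four compounds keep a substituted or plain phenyl on this nitrogen, which leaves open whether a ring carrying an amine or a carboxylic acid, or a simple alkyl chain in place of the phenyl, would move the number beyond the scatter. Going by these compounds, whether a change to the shared core would do so also remains open.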